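A few compounds are considered here, and "the series" means these few. Any claim that something is new, unique, unknown or untested is made for them only; others in the source may bear on it.

Measured in an ADME assay on the whole organism (plasma, Rattus norvegicus, strain Han Wistar) for pharmacokinetics, at a dose of 1.2 umol/kg by the intravenous route; on this read-out lower numbers stand for slow clearance and higher numbers for fast clearance:
Compound 1 `CC(=O)N[C@@H]1CCC[C@H](C(=O)Nc2cc(-c3cnn4c3CCCC4)c(Cl)cn2)C1`: 78 mL/min/kg
Compound 2 `CC(=O)N[C@@H]1CCC[C@H](C(=O)Nc2cc(-c3cnn4c3CC(C)(C)C4)c(F)cn2)C1`: 104 mL/min/kg

Clearance describes how quickly the body removes a compound from the plasma. Compound 2, at 104 mL/min/kg, stands within the usual scatter of compound 1, at 78 mL/min/kg, so repeated measurements could not reliably separate the two.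

The next compound to be tested is compound 3 `CC(=O)N[C@@H]1CCC[C@H](C(=O)Nc2cc(-c3cnn4c3CC(C)(C)C4)c(Cl)cn2)C1`. It keeps the structure of compound 2 but has chloro in place of fluoro on an aromatic carbon. Within the data shown here, no measured pair differs in one place only, so the effect of this exchange has not been seen directly. Compound 1 also carries chloro on that carbon and gives 78 mL/min/kg, but the rest of its structure differs, which makes it only a loose guide.

In this assay, no step beyond the scatter is expected. The estimated change is a 1.2-fold lower number from compound 2 to compound 3 (0.06 log units; within the scatter).

For compound 3, the estimated clearance is 90 mL/min/kg, with an expected range of 55 mL/min/kg to 140 mL/min/kg.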

Compound 3, clearance: 71 mL/min/kg
Beside the measured number, compound 3's estimate is 1.3-fold (0.10 log units) above it; the measured number falls inside the stated range.
By their numbers in this assay, from the lowest: compounds 3, 1 and 2 (each within the scatter of the next).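

In this assay, the exchange of chloro for fluoro on this aromatic carbon can now be read directly, and it gives a 1.5-fold lower number from compound 2 to compound 3 (0.17 log units; within the scatter). This places the two halogens within the normal spread of repeated measurements in this setting, so the exchange has no effect here that can be told apart from that spread, and the same holds for the change in the other group on the shared core, with chloro kept in place, which gives a 1.1-fold lower number from compound 1 to compound 3 (0.04 log units; within the scatter). Nothing measured alongside these numbers explains them.

Among these compounds, the three compounds therefore show only that these two particular exchanges leave clearance unresolved, and they do not show whether this position can influence it at all. As far as these compounds go, whether a nitrile, a methoxy group or an amine on the same aromatic carbon would give a step beyond the scatter remains open, as does whether a change elsewhere, such as replacing the acetyl group on the amide nitrogen with a longer chain, would do so.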